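Chloro for Bromo: What Compound 3 Might Give

The compounds below may be only part of what the source reports. "The series", "measured", "known", "first", "only" and "open" are said of these compounds alone.

Of the compounds shown here, two have numbers so far. Compound 1 `Brc1ccccc1COc1nc2ccccc2s1` gives 51.9% in a functional assay on the whole organism with Mus musculus as the target, in the writhing test, at a dose of 100 mg/kg by the intraperitoneal route; on this read-out higher numbers stand for more inhibition at the one dose given (going by the name of the read-out) and lower numbers for less inhibition. Compound 2 `Brc1ccc(OCCOc2nc3ccccc3s2)cc1` gives 68.6% in this assay. Compound 1 therefore stands lowest of the two, with compound 2 higher by a margin beyond the usual scatter. Compound 3 `Clc1ccccc1COc1nc2ccccc2s1` has not yet been measured. It differs from compound 1 in one place: chloro in place of bromo on an aromatic carbon. For the measured compounds named here, no pair of measured compounds shows this exchange, so its size cannot be read from the data. Swapping one halogen for another, with nothing else altered, is expected to move the number little, if at all, and the step of a number 1.9 percentage points lower from compound 1 to compound 3 (within the scatter) is expected to lie within the scatter. Compound 3 is accordingly estimated at 50%, with a range from 30% to 70%.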

Compound 3, a percentage reported as inhibition, in the whole organism at one dose (the size of the read-out at that dose, not a potency): "not active" (no number reported)
Compound 3 has no reported number here, and the estimate cannot be compared.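

For the compounds shown here, compound 3 is reported as "not active" with no number, so in this assay no step from compound 1 to compound 3 can be read. Nothing available bears on this result. On these data alone, how far the exchange of bromo for chloro moves the inhibition remains open.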